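Halogen Exchange on the Aryl Ester Group

This account rests on a few compounds, and the source may have more. Where it says the series, first, only, none or still open, it means among the compounds named here.

Compound 2 `COC(=O)c1ccc(Cl)cc1OC(=O)COc1cc(O)c2c(=O)cc(-c3ccccc3)oc2c1` was examined in an ADME assay on cells (T-cell, Mus musculus, strain BALB/c) for cytotoxicity, read by MTT assay, with a stated time of 48 h (a lower number here means that less compound is tolerated, a higher number that more compound is tolerated), where compound 2 gave 265000 nM. Among the compounds with values here, compound 1 `COC(=O)c1c(F)cccc1OC(=O)COc1cc(O)c2c(=O)cc(-c3ccccc3)oc2c1` gave 319000 nM in this assay; the step of a 1.2-fold lower number from compound 1 to compound 2 (0.08 log units; within the scatter) lies within the scatter, so the two compounds cannot be told apart, and compound 2 stands alongside compound 1 as one of only two numbers so far. Compound 3 `COC(=O)c1c(Br)cccc1OC(=O)COc1cc(O)c2c(=O)cc(-c3ccccc3)oc2c1` has not yet been measured. It differs from compound 2 by a group of 11 heavy atoms (8 carbon, 2 oxygen, 1 bromine; one six-membered aromatic ring of carbon only) in place of a group of 11 heavy atoms (8 carbon, 2 oxygen, 1 chlorine; one six-membered aromatic ring of carbon only), on an oxygen next to a carbonyl group. Within the data shown here, the only measured step that bears on this change, a 1.2-fold lower number from compound 1 to compound 2 (0.08 log units; within the scatter), likewise replaced one such group with another and stayed within the scatter. Compound 3 is therefore expected to give a number close to that of compound 2, with a step of a 1.1-fold higher number from compound 2 to compound 3 (0.02 log units; within the scatter) that should not go beyond the scatter. The estimate for compound 3 in this assay is 280000 nM, between 150000 nM and 520000 nM.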

Compound 3, half-maximal cytotoxic concentration: 388000 nM
For compound 3 the middle estimate is 1.4-fold (0.14 log units) below the measured one; the range from low to high includes it.
By their numbers in this assay, from the lowest: compounds 2, 1 and 3 (each within the scatter of the next).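

In this assay, bromo in place of fluoro on an aromatic carbon gives a 1.2-fold higher number from compound 1 to compound 3 (0.09 log units; within the scatter), the first step shown that exchanges one halogen for another on the same carbon, and it leaves the compounds indistinguishable. The exchange of the 5-chloro-2-(methoxycarbonyl)phenyl group for the group carrying bromine gives a 1.5-fold higher number from compound 2 to compound 3 (0.17 log units; within the scatter), so all three halogen-bearing aryl esters now lie within the scatter of one another, with fluorine, chlorine and bromine alike. No measurement is available that would account for these numbers.

The compounds shown cover only halogens on this aromatic ring, so they leave open whether an amine or a methoxy group there would stay within the scatter. They also leave open what a carboxylic acid in place of the methoxycarbonyl group would give.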